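A few compounds are considered here, and "the series" means these few. Any claim that something is new, unique, unknown or untested is made for them only; others in the source may bear on it.

Measured so far in an assay on isolated protein for inhibition of Rho-associated protein kinase 1 (Homo sapiens), read by scintillation counting, radiometric assay and 33P incorporation, with a stated time of 40 min, in the presence of a further agent that is not named here; on this read-out higher numbers stand for weaker inhibition and lower numbers for stronger inhibition:
compound 1 `CCCC(=O)Nc1cccc(NC(=O)COc2ccc3c(=O)ccoc3c2)c1` gives 1430 nM
compound 2 `COC(=O)c1ccc(C(=O)Nc2cccc(NC(=O)COc3ccc4c(=O)ccoc4c3)c2)cc1` gives 72 nM
compound 3 `O=C(COc1ccc2c(=O)ccoc2c1)Nc1cccc(NC(=O)c2cccc([N+](=O)[O-])c2)c1` gives 528 nM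

Among these three numbers compound 3 holds the second highest: against compound 1 the step is a 2.7-fold lower number from compound 1 to compound 3 (0.43 log units; beyond the scatter), and against compound 2 it is a 7.3-fold higher number from compound 2 to compound 3 (0.87 log units; beyond the scatter). All three compounds share one core and differ only in the group attached to a carbonyl carbon whose other neighbour is an amide-type nitrogen, so every measured step reports on that single position. The step of a 20-fold lower number from compound 1 to compound 2 (1.30 log units; beyond the scatter) was large, the other two were modest, which shows that exchanging the group at this position can move the number considerably, but not always by much. Compound 4 `CC(C)(C)c1cc(C(=O)Nc2cccc(NC(=O)COc3ccc4c(=O)ccoc4c3)c2)no1` is not yet measured; its change from compound 3 is 5-(tert-butyl)-1,2-oxazol-3-yl in place of 3-nitrophenyl on a carbonyl carbon. For the measured compounds named here, no measured step exchanges one aromatic ring for another of a different kind, so the direction is open; an aromatic ring is kept here, and both measured aromatic groups gave lower numbers than the propyl of compound 1. In this assay compound 4 is expected to give 400 nM, with a range from 100 nM to 1600 nM. This estimate means an expected step of a 1.3-fold lower number from compound 3 to compound 4 (0.12 log units; within the scatter), close to the scatter.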

Compound 4, half-maximal inhibitory concentration: 101 nM
The estimate for compound 4 lay 4.0-fold (0.60 log units) above the measured number; the measured number falls inside the stated range.
By their numbers in this assay, from the lowest: compounds 2 and 4 (each within the scatter of the next); then compound 3; then compound 1.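

The 5-(tert-butyl)-1,2-oxazol-3-yl group shows that the group on this carbonyl carbon need not be a six-membered aromatic ring of carbon only: replacing 3-nitrophenyl gives a 5.2-fold lower number from compound 3 to compound 4 (0.72 log units; beyond the scatter) and replacing propyl gives a 14-fold lower number from compound 1 to compound 4 (1.15 log units; beyond the scatter). Against the 4-(methoxycarbonyl)phenyl group the step is a 1.4-fold higher number from compound 2 to compound 4 (0.15 log units; within the scatter), so these two differently built aromatic groups cannot be told apart at this position. No measurement at hand speaks to what lies behind these differences.

The compounds shown carry the tert-butyl group and the five-membered ring only together, so the share of each in this step stays open. Also open, going by these compounds, is how an amine or a carboxylic acid on the ring, or a longer chain in place of propyl, would read at this position.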